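The source may report more compounds than this note shows. Statements on the series, on what has been measured and on what is new or still open speak of the compounds shown alone.

Measured so far:
- compound 1, `C=C(Br)C(=O)Nc1cccc(/C=C2\SC(=O)N(Cc3ccc(Cl)cc3)C2=O)c1`: 1600 nM
- compound 2, `Nc1ccc(/C=C2\SC(=O)N(Cc3ccc(Cl)cc3)C2=O)cc1`: 60000 nM

In a functional assay on FM3A cells (Mus musculus) for cytotoxicity, read by cell counting, with a stated time of 2 days (on this read-out higher numbers stand for weaker inhibition and lower numbers for stronger inhibition), compound 2 gives the highest of the two numbers; compound 1 gives the lower one, and the gap between them lies beyond the scatter. Compound 3, `CCN1C(=O)S/C(=C\c2ccc(N)cc2)C1=O`, differs from compound 2 by methyl in place of 4-chlorophenyl on a saturated chain carbon bound to an amide-type nitrogen in a ring. For the measured compounds named here, no step between measured compounds is available to weigh this change; the 4-chlorophenyl is present in both compounds that have been measured. A modest upward step in this assay is expected, with the scatter leaving room for none at all. For compound 3 the expected value in this assay is 100000 nM, within 30000 nM to 300000 nM, an estimated step of a 1.7-fold higher number from compound 2 to compound 3 (0.22 log units; within the scatter).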

Compound 3, half-maximal inhibitory concentration: 76000 nM
Estimate against measurement, compound 3: 1.3-fold (0.12 log units) above; the range from low to high includes it.
By their numbers in this assay, from the lowest: compound 1; then compounds 2 and 3 (each within the scatter of the next).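

In this assay methyl in place of 4-chlorophenyl gives a 1.3-fold higher number from compound 2 to compound 3 (0.10 log units; within the scatter) and so leaves compound 2 and compound 3 indistinguishable. At this place, on a saturated chain carbon bound to an amide-type nitrogen in a ring, the 4-chlorophenyl is therefore not needed to hold the read-out at the level of compound 2. No measurement at hand accounts for this result. Still open, from the compounds shown here alone, is whether a longer chain, a carboxylic acid or an amine at this place would depart from these two compounds. Also open, going by these compounds, is whether the same exchange would read alike on the core of compound 1.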